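Swapping the aromatic group on the sulfur-linked chain

The compounds below may be only part of what the source reports. "The series", "measured", "known", "first", "only" and "open" are said of these compounds alone.

Measured so far in a functional assay on KB cells (Homo sapiens) for inhibition; a lower number here means a stronger inhibitor, a higher number a weaker inhibitor:
- Compound 1 `N#CCSc1nc2cc(Cl)c(Cl)cc2n1C1O[C@H](CO)[C@@H](O)[C@H]1O` gives > 100000 nM (a limit of the assay)
- Compound 2 `COc1ccc(CSc2nc3cc(Cl)c(Cl)cc3n2C2O[C@H](CO)[C@@H](O)[C@H]2O)cc1` gives 41000 nM

Among the measured compounds shown here, of these two results, only the one for compound 2 is a true number, at 41000 nM in this assay. The result for compound 1 is a limit.

The next compound, compound 3 `OC[C@H]1OC(n2c(SCc3ccccc3Cl)nc3cc(Cl)c(Cl)cc32)[C@H](O)[C@@H]1O`, has not yet been measured. It carries 2-chlorophenyl in place of 4-methoxyphenyl on a saturated chain carbon bound to a sulfur.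

For the measured compounds named here, only one measured step bears on this change: an at least 2.4-fold lower number from compound 1 to compound 2 (0.38 log units; beyond the scatter). That step replaced cyano with an aromatic ring, whereas the new change replaces one aromatic ring with another, so it offers only indirect guidance. Compound 3 keeps such a ring, so a result close to that of compound 2 at 41000 nM is expected, with no step beyond the scatter in this assay.

The estimated change is a 1.0-fold lower number from compound 2 to compound 3 (0.01 log units; within the scatter) for this pair.

For compound 3, the expected value is 40000 nM, with an estimated range from 15000 nM to 100000 nM.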

Compound 3, half-maximal inhibitory concentration: 30000 nM
Compound 3: middle estimate off by 1.3-fold (0.12 log units), on the high side, and the stated range covers the measured number.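

In this assay, the exchange of 4-methoxyphenyl for 2-chlorophenyl on the saturated chain carbon bound to a sulfur gives a 1.4-fold lower number from compound 2 to compound 3 (0.14 log units; within the scatter), so this position tolerates the exchange of one substituted aromatic ring for another, with methoxy replaced by chlorine, without a readable change. The second ring also gives an at least 3.3-fold lower number from compound 1 to compound 3 (0.52 log units; beyond the scatter), which means that the difference from the cyano compound now holds for two different aromatic groups rather than for one. That step has only a lower bound, as the result for compound 1 is a limit of the assay and not a number: the limit of > 100000 nM in this assay, at which 1 of the 3 values shown sits.

The compounds shown leave open whether an aromatic ring is needed at all for the difference from cyano, or whether a longer chain of plain carbon on the sulfur would serve as well. They also leave open what an amine or a carboxylic acid on the ring would do, and whether any group at this position can bring the number well below those of compound 2 and compound 3.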